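Methylation of the free hydroxy on two related cores

The source may hold more compounds than are shown below. What is called first, only, known or untested is meant among the compounds shown, and "the series" means these compounds.

Of the compounds shown here, three have been measured in a functional assay on CNE-2 cells (Homo sapiens) for antiproliferative activity, read by sulforhodamine B assay, with a stated time of 48 h; a lower number here means a stronger inhibitor, a higher number a weaker inhibitor. Compound 1 `COc1ccc(C=C(C(=O)/C=C/c2cccc(OC)c2OC)C(=O)/C=C/c2cccc(OC)c2OC)cc1OC` gives 280 nM. Compound 2 `COc1ccc(C=C(C(=O)/C=C/c2cccc(OC)c2OC)C(=O)/C=C/c2cccc(OC)c2OC)cc1O` gives 220 nM in this assay. Compound 3 `COc1ccc(OC)c(/C=C/C(=O)C(=Cc2ccc(O)c(OC)c2)C(=O)/C=C/c2cc(OC)ccc2OC)c1` gives 340 nM in this assay. All three values fall within the usual scatter of one another, so no order among them is drawn.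

The change from compound 2 to compound 1 is methyl in place of hydrogen on an oxygen on an aromatic ring. The step it made was a 1.3-fold higher number from compound 2 to compound 1 (0.10 log units; within the scatter).

Compound 4 `COc1ccc(OC)c(/C=C/C(=O)C(=Cc2ccc(OC)c(OC)c2)C(=O)/C=C/c2cc(OC)ccc2OC)c1` has not yet been measured. It differs from compound 3 by methyl in place of hydrogen on an oxygen on an aromatic ring. The place of this change reads the same as for the earlier pair, so it is the same change applied to a different core. Compound 3 and compound 2 are built from the same atoms joined differently; the difference between the two cores is not broken down here.

Compound 4 is expected to give 400 nM in this assay. The expected range for compound 4 runs from 200 nM to 800 nM. The step this estimate means is a 1.2-fold higher number from compound 3 to compound 4 (0.07 log units; within the scatter), expected because the only earlier occurrence of the same change gave a 1.3-fold higher number from compound 2 to compound 1 (0.10 log units; within the scatter). The estimate rests on one pair alone, and on a core whose relation to that of compound 3 is not counted here, so the range is kept wide.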

Compound 4, half-maximal inhibitory concentration: 550 nM
For compound 4 the middle estimate is 1.4-fold (0.14 log units) below the measured one, and the stated range covers the measured number.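

In this assay, the change from 4-hydroxy-3-methoxyphenyl to 3,4-dimethoxyphenyl, methyl in place of hydrogen on an oxygen on an aromatic ring, gives a 1.6-fold higher number from compound 3 to compound 4 (0.21 log units; within the scatter). Set beside the earlier pair, the change reads alike on both cores, with no difference between the two steps that can be told from the scatter: the same change on two cores in this assay, a 1.3-fold higher number (0.10 log units; within the scatter) from compound 2 to compound 1 and a 1.6-fold higher number (0.21 log units; within the scatter) from compound 3 to compound 4, 1.3-fold (0.10 log units) apart, within the scatter of two such steps. This supports treating the hydroxy and methoxy forms as not distinguishable in this assay on these two cores, but each step lies within the scatter on its own, so neither shows that methylation weakens activity, and two pairs give no rule for the rest of the series.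

The oxygen carries only hydrogen or methyl in the compounds shown, so it stays open whether an ethyl group, a longer chain, or a chain ending in an amine or a carboxylic acid would also leave the number within the scatter of the hydroxy compound. How the same change reads on any core other than these two is open as well, and so is whether a step beyond the scatter appears there.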